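Replacing the Amide Side Chain with a Difluorophenyl Ring

The compounds below may be only part of what the source reports. "The series", "measured", "known", "first", "only" and "open" are said of these compounds alone.

Measured in a functional assay on HepG2 cells (Homo sapiens) for inhibition, read by MTT assay, with a stated time of 48 h; a lower number here means a stronger inhibitor, a higher number a weaker inhibitor:
compound 1 `O=C(CCCCc1ccccc1)Nc1ccc(N2CCN(c3ccc(OC[C@@H]4CO[C@@](Cn5cncn5)(c5ccc(Cl)cc5Cl)O4)cc3)CC2)cc1` gives 7010 nM
compound 2 `O=C(CCc1ccccc1)Nc1ccc(N2CCN(c3ccc(OC[C@@H]4CO[C@@](Cn5cncn5)(c5ccc(Cl)cc5Cl)O4)cc3)CC2)cc1` gives 5340 nM

Compound 2 stands lowest of the two numbers in this assay, though its nearest neighbour, compound 1, sits within the scatter of it. Compound 3 `O=C(Nc1ccc(N2CCN(c3ccc(OC[C@@H]4CO[C@@](Cn5cncn5)(c5ccc(Cl)cc5Cl)O4)cc3)CC2)cc1)c1ccc(F)c(F)c1` carries 3,4-difluorophenyl in place of phenethyl on a carbonyl carbon. Within the data shown here, the one measured step, a 1.3-fold lower number from compound 1 to compound 2 (0.12 log units; within the scatter), also shortened the chain between the amide and the aromatic ring without a change beyond the scatter, so another small step or none is expected here. The expected step is a 1.1-fold lower number from compound 2 to compound 3 (0.03 log units; within the scatter). Compound 3 is therefore estimated at 5000 nM, with a range from 2000 nM to 13000 nM.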

Compound 3, half-maximal inhibitory concentration: 19900 nM
Compound 3: middle estimate off by 4.0-fold (0.60 log units), on the low side; the whole stated range lies below it.
By their numbers in this assay, from the lowest: compounds 2 and 1 (each within the scatter of the next); then compound 3.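

Moving to 3,4-difluorophenyl on the carbonyl carbon gives a 3.7-fold higher number from compound 2 to compound 3 (0.57 log units; beyond the scatter) and a 2.8-fold higher number from compound 1 to compound 3 (0.45 log units; beyond the scatter) in this assay, so this position does respond to change, although the phenethyl and 4-phenylbutyl chains gave no separable numbers. Compound 3 is the weakest inhibitor of the three. Nothing available here explains this rise. Still open, going by these compounds, is whether the rise follows from losing the chain or from adding the fluorine atoms. An unsubstituted phenyl or a benzyl group on the same carbonyl carbon would separate the two.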